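The compounds below may be only part of what the source reports. "The series", "measured", "known", "first", "only" and "open" are said of these compounds alone.

Three compounds share one core and differ only in the amine that ends a chain attached through an oxygen on an aromatic ring. Compound 1 `CN(C)CCCCCCCCCOc1ccc2oc(-c3ccccc3)cc(=O)c2c1` carries a 3-(dimethylamino)propyl group there; in an assay on isolated protein (Cavia porcellus) with Sigma non-opioid intracellular receptor 1 (Homo sapiens) as the target, read by radioligand binding (a higher number here means a weaker inhibitor, a lower number a stronger inhibitor), compound 1 gives 202 nM. Compound 2 `O=c1cc(-c2ccccc2)oc2ccc(OCCCCCCN3CCC(O)CC3)cc12` carries a 4-hydroxypiperidin-1-yl group, and in this assay compound 2 gives 121 nM. Compound 3 `O=c1cc(-c2ccccc2)oc2ccc(OCCCCCCN3CCCCC3)cc12` carries a plain piperidin-1-yl group; in this assay compound 3 gives 54 nM, the lowest of the three numbers, reached by a 3.7-fold lower number from compound 1 to compound 3 (0.57 log units; beyond the scatter) and by a 2.2-fold lower number from compound 2 to compound 3 (0.35 log units; beyond the scatter).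

Compound 4 `O=c1cc(-c2ccccc2)oc2ccc(OCCCCCCN3CCNC(CCO)C3)cc12` takes the next step: 3-(2-hydroxyethyl)piperazin-1-yl in place of piperidin-1-yl on a saturated chain carbon, six bonds along the chain from an oxygen on an aromatic ring. For the measured compounds named here, the only measured step that touches the same kind of change is a 2.2-fold lower number from compound 2 to compound 3 (0.35 log units; beyond the scatter), where removing a hydroxy lowered the number; compound 4 moves the other way, bringing a hydroxyethyl group and a second ring nitrogen into the ring. A modest rise in the number is therefore expected, roughly a 2.4-fold higher number from compound 3 to compound 4 (0.38 log units; beyond the scatter). The estimate for compound 4 is 130 nM, with a likely range from 55 nM to 310 nM.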

Compound 4, half-maximal inhibitory concentration: 94 nM
Compound 4: the middle estimate sits 1.4-fold (0.14 log units) above what was measured, within the range that was stated.
By their numbers in this assay, from the lowest: compounds 3, 4, 2 and 1 (each within the scatter of the next, the first and the last beyond it).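

In this assay, replacing piperidin-1-yl with the heavier 3-(2-hydroxyethyl)piperazin-1-yl at this chain end gives a change that stays within the scatter (a 1.7-fold higher number from compound 3 to compound 4 (0.24 log units; within the scatter)), so adding a second ring nitrogen and a 2-hydroxyethyl group does not clearly move the number. Exchanging 4-hydroxypiperidin-1-yl for the same group also stays within the scatter (a 1.3-fold lower number from compound 2 to compound 4 (0.11 log units; within the scatter)), whereas exchanging 3-(dimethylamino)propyl for it gives a step beyond the scatter (a 2.1-fold lower number from compound 1 to compound 4 (0.33 log units; beyond the scatter)). Nothing shown here bears on why the numbers fall this way.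

The compounds shown leave open how a plain piperazin-1-yl group, without the 2-hydroxyethyl group, or a morpholin-4-yl group would compare at this position. Also open, from the compounds shown here alone, is how a shorter or longer chain carrying 3-(2-hydroxyethyl)piperazin-1-yl would read.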